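Replacing the triazolyl group: an expected recovery in response

The compounds below may be only part of what the source reports. "The series", "measured", "known", "first", "only" and "open" are said of these compounds alone.

Compound 2 `CC1(OC(=O)N2CC3COCC(C2)C3Oc2ncnc(Nc3ccc(-n4cncn4)cc3F)c2F)CC1` gives 73% in a functional assay on HEK293 cells for agonist activity at Glucose-dependent insulinotropic receptor (Homo sapiens), read by cAMP accumulation, with a stated time of 30 min (a higher number here means a larger maximal response, a lower number a smaller maximal response), the lower of the two numbers measured in this study; compound 1 `CC1(OC(=O)N2CC3COCC(C2)C3Oc2ncnc(Nc3ccc(F)cc3F)c2F)CC1` gives 94% in this assay. Among the measured compounds shown here, the single measured step, a number 21 percentage points lower from compound 1 to compound 2 (beyond the scatter), alters the same region of the molecule and is the only one that bears on the present change. Compound 3 `CC1(OC(=O)N2CC3COCC(C2)C3Oc2ncnc(Nc3cccnc3Cl)c2F)CC1` differs from compound 2 by a group of 7 heavy atoms (5 carbon, 1 nitrogen, 1 chlorine; one six-membered aromatic ring with 1 hetero atom) in place of a group of 12 heavy atoms (8 carbon, 3 nitrogen, 1 fluorine; one five-membered aromatic ring with 3 hetero atoms, one six-membered aromatic ring of carbon only), on a nitrogen on an aromatic ring. The change removes the group whose introduction accompanied the drop seen in the measured step and puts a smaller ring in its place. For the measured compounds named here, a recovery toward the level of compound 1, which gives 94% in this assay, appears more likely than a further fall, although no measured step covers this exact exchange. Compound 3 is therefore expected to give 85% in this assay, within 65% to 100%. The estimated step of a number 12 percentage points higher from compound 2 to compound 3 (beyond the scatter) is expected to lie beyond the scatter.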

Compound 3, largest response reached (reported as percent of maximum), in percent of the reference or control that the assay uses: 63%
Beside the measured number, compound 3's estimate is 22 percentage points above it; measured number outside the range, below it.
By their numbers in this assay, from the lowest: compounds 3 and 2 (each within the scatter of the next); then compound 1.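

In this assay, the exchange on the nitrogen on an aromatic ring gives a number 10 percentage points lower from compound 2 to compound 3 (within the scatter), so the 2-chloropyridin-3-yl group and the triazole-bearing group it replaces cannot be told apart at this position. Measured against the 2,4-difluorophenyl group, the same 2-chloropyridin-3-yl group gives a number 31 percentage points lower from compound 1 to compound 3 (beyond the scatter), which shows that removing the triazole ring does not by itself restore the higher response. No measurement shown here accounts for this result.

The pyridine nitrogen and the chlorine enter together, which leaves open how much of the step from the 2,4-difluorophenyl group belongs to each. Also open, going by these compounds, is how the response in this assay would read with a morpholine or a carboxylic acid on the aromatic carbon that carries the fluoro group in compound 1.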